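The source may report more compounds than this note shows. Statements on the series, on what has been measured and on what is new or still open speak of the compounds shown alone.

Measured compounds:
compound 1 `CC(C)(N)C(=O)N[C@H](COCc1ccc(F)cc1F)c1nnnn1CCOC(=O)NCCCCO` — 0.42 nM
compound 2 `CC(C)(N)C(=O)N[C@H](COCc1cccc(Cl)c1Cl)c1nnnn1CCOC(=O)NCCCCO` — 0.61 nM
compound 3 `CC(C)(N)C(=O)N[C@H](COCc1cccc(OC(F)(F)F)c1)c1nnnn1CCOC(=O)NCCCCO` — 3.1 nM

In a functional assay on cells for inhibition of growth hormone secretagogue receptor type 1 (Homo sapiens), read by FLIPR and calcium flux (on this read-out lower numbers stand for an effect already at smaller amounts and higher numbers for an effect only at larger amounts of compound), compound 2 gives 0.61 nM, the second highest of the three numbers. Its closest neighbour is compound 1, and a 1.5-fold higher number from compound 1 to compound 2 (0.16 log units; within the scatter); the furthest is compound 3, and a 5.1-fold higher number from compound 2 to compound 3 (0.71 log units; beyond the scatter). Compound 4 `CC(C)(N)C(=O)N[C@H](COCC1CCCCC1)c1nnnn1CCOC(=O)NCCCCO` has not yet been measured in this assay. It differs from compound 2 in one place: cyclohexyl in place of 2,3-dichlorophenyl on a saturated chain carbon bound to an oxygen on a saturated carbon.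

Every measured step in this series exchanges one six-membered aromatic ring for another on the same saturated chain carbon bound to an oxygen on a saturated carbon. Two of those exchanges, a 7.4-fold higher number from compound 1 to compound 3 (0.87 log units; beyond the scatter) and a 5.1-fold higher number from compound 2 to compound 3 (0.71 log units; beyond the scatter), move the number upward by a modest amount, while a 1.5-fold higher number from compound 1 to compound 2 (0.16 log units; within the scatter) stays within the scatter. For the measured compounds named here, no measured step replaces the aromatic ring by a non-aromatic ring, so the present change has no direct precedent here. Given that even aromatic-to-aromatic changes reached modest steps upward, compound 4 is expected to show an upward step, a 4.9-fold higher number from compound 2 to compound 4 (0.69 log units; beyond the scatter), of similar or somewhat larger size. Compound 4 is therefore estimated at 3 nM, with a range from 0.6 nM to 15 nM.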

Compound 4, half-maximal effective concentration: 1.66 nM
For compound 4 the middle estimate is 1.8-fold (0.26 log units) above the measured one, within the range that was stated.
By their numbers in this assay, from the lowest: compounds 1 and 2 (each within the scatter of the next); then compounds 4 and 3 (each within the scatter of the next).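

In this assay, for the compounds shown here, the cyclohexyl group is the first non-aromatic ring seen on this saturated chain carbon bound to an oxygen on a saturated carbon, and it shows that an aromatic ring is not required for activity at this position. The exchange carries a modest cost against the two halogenated rings, with a 2.7-fold higher number from compound 2 to compound 4 (0.43 log units; beyond the scatter) and a 4.0-fold higher number from compound 1 to compound 4 (0.60 log units; beyond the scatter), whereas a 1.9-fold lower number from compound 3 to compound 4 (0.27 log units; within the scatter) leaves cyclohexyl indistinguishable from 3-(trifluoromethoxy)phenyl, so the step depends on which aromatic ring is replaced. Nothing in the available evidence accounts for these differences.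

The compounds shown leave open whether the step from compound 2 to compound 4 follows from the loss of the aromatic ring or of the two chlorine atoms, since the change removes both, and an unsubstituted phenyl group would be needed to tell these apart. Going by these compounds alone, also open is how far non-aromatic rings in general are accepted here, as cyclohexyl is the only example, and a cyclopentyl group, a 4,4-difluorocyclohexyl group or a piperidine ring with its ring amine could each answer differently.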